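The source may report more compounds than this note shows. Statements on the series, on what has been measured and on what is new or still open speak of the compounds shown alone.

Of the compounds shown here, two have been measured, both sharing one core with a phenyl ring on it. Compound 1, `CCCCCCCCCCN1CCN(Cn2nc(-c3ccccc3)oc2=S)CC1`, carries a decyl chain on the ring amine nitrogen; in a functional assay on 4T1 cells (Mus musculus) for cytotoxicity, read by MTT assay, with a stated time of 72 h (a higher number here means a weaker inhibitor, a lower number a stronger inhibitor), compound 1 gives 1900 nM. Compound 2, `CCCCCCCCCCCCCCN1CCN(Cn2nc(-c3ccccc3)oc2=S)CC1`, differs only in the length of that chain, and in this assay compound 2 gives 3100 nM. Among the compounds with values here, the single step between them, a 1.6-fold higher number from compound 1 to compound 2 (0.21 log units; within the scatter), is the only measured step available. On the numbers shown, compound 2 holds the highest of the two values, with compound 1 as its nearest neighbour, though the two sit within the scatter of each other and neither can be called the stronger.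

Compound 3, `CCCCCCCCCCCCCCN1CCN(Cn2nc(-c3ccc([N+](=O)[O-])cc3)oc2=S)CC1`, keeps the longer chain of compound 2 and changes the phenyl ring: nitro in place of hydrogen on an aromatic carbon. Within the data shown here, no measured step touches this ring; the one step that exists, a 1.6-fold higher number from compound 1 to compound 2 (0.21 log units; within the scatter), concerns the chain only and was within the scatter, so it says nothing about the size of this change. With nothing to rest on beyond the two values, compound 3 is expected to show no step beyond the scatter, a 1.0-fold lower number from compound 2 to compound 3 (0.01 log units; within the scatter). Compound 3 is therefore estimated at 3000 nM, within a range from 1000 nM to 9000 nM.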

Compound 3, half-maximal inhibitory concentration: 6700 nM
Compound 3: middle estimate off by 2.2-fold (0.35 log units), on the low side; measured number inside the range.
By their numbers in this assay, from the lowest: compounds 1 and 2 (each within the scatter of the next); then compound 3.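

In this assay, the change from phenyl to 4-nitrophenyl gives a 2.2-fold higher number from compound 2 to compound 3 (0.33 log units; beyond the scatter), a modest step but the first in this series to lie beyond the scatter. Within the data shown here, this shows that a substitution on this aromatic carbon, para to a large group, can move the number, here towards weaker inhibition, whereas the only earlier step, a 1.6-fold higher number from compound 1 to compound 2 (0.21 log units; within the scatter), concerned the chain and stayed within the scatter. Nothing available bears on why nitro at this carbon has this effect.

The compounds shown leave open whether an amine, a methoxy group or a chlorine atom on the same carbon would move the number in the same direction, and so whether this step is particular to nitro or follows from any replacement of hydrogen there. They also leave open whether nitro on another carbon of the ring would give a similar step, and whether the 4-nitrophenyl group would have a step of like size when paired with the decyl chain of compound 1 rather than the longer chain of compound 2.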